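The compounds below may be only part of what the source reports. "The series", "measured", "known", "first", "only" and "open" are said of these compounds alone.

For the measured compounds named here, in a physicochemical assay for solubility, at pH 7.4 (a lower number here means a less soluble compound, a higher number a more soluble compound), three compounds have numbers so far. Compound 1 `C[C@H]1[C@H](N)CN1c1nc2c(cc1F)c(=O)c(C(=O)O)cn2C1CC1` gives 20.3 ug/mL, compound 2 `CC[C@H]1[C@@H](N)CN1c1c(F)cc2c(=O)c(C(=O)O)cn(C3CC3)c2c1F` gives 55.9 ug/mL, and compound 3 `CNC1CN(c2c(F)cc3c(=O)c(C(=O)O)cn(C4CC4)c3c2F)C1` gives 1.7 ug/mL, the lowest of the three and beyond the scatter from both others.

The next compound, compound 4 `C[C@H]1[C@H](N)CN1c1c(F)cc2c(=O)c(C(=O)O)cn(C3CC3)c2c1F`, keeps the core of compound 3 but replaces its 3-(methylamino)azetidin-1-yl group on an aromatic carbon: a group of 6 heavy atoms (4 carbon, 2 nitrogen; one four-membered non-aromatic ring with 1 hetero atom) in place of a group of 6 heavy atoms (4 carbon, 2 nitrogen; one four-membered non-aromatic ring with 1 hetero atom), on an aromatic carbon. The two compounds have the same atoms, joined differently, and the entering group has defined stereocentres.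

The closest evidence is a 33-fold lower number from compound 2 to compound 3 (1.52 log units; beyond the scatter), a large step beyond the scatter. Compound 2 shares the core of compound 4 and also has a substituted azetidine ring, but it carries ethyl where compound 4 carries methyl and differs at one stereocentre. The group of compound 4 also appears on a different core in compound 1, which gives 20.3 ug/mL, and compound 3 lies under that value. Neither comparison isolates this exchange, but both point the same way, so a large rise in this assay is expected. The expected step is an 18-fold higher number from compound 3 to compound 4 (1.25 log units; beyond the scatter). Compound 4 is estimated at 30 ug/mL, with an expected range of 10 ug/mL to 90 ug/mL.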

Compound 4, solubility: 23.2 ug/mL
The estimate for compound 4 lay 1.3-fold (0.11 log units) above the measured number; measured number inside the range.
By their numbers in this assay, from the lowest: compound 3; then compounds 1 and 4 (each within the scatter of the next); then compound 2.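

Measured in this assay, the rearrangement at this aromatic carbon, ortho to two fluoro groups, gives a 14-fold higher number from compound 3 to compound 4 (1.14 log units; beyond the scatter) while the counts of heavy atoms, hydrogen-bond donors and hydrogen-bond acceptors stay the same, so a large change here does not need any change in those counts. The other new step, a 2.4-fold lower number from compound 2 to compound 4 (0.38 log units; beyond the scatter), is modest but beyond the scatter, and it shows that the two groups with defined stereocentres are not interchangeable in this read-out, although it cannot separate methyl against ethyl from the difference at one stereocentre. The step from 3-(methylamino)azetidin-1-yl is also a composite, since the entering group differs both in how its atoms are joined and in having 2 defined stereocentres, so the share of each in the change cannot be read from these compounds.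

The compounds shown leave open how a longer chain such as propyl in place of the methyl on the four-membered ring would read, and how the mirror-image forms of the entering group would compare. Nothing given here bears on what lies behind these steps.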